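This account rests on a few compounds, and the source may have more. Where it says the series, first, only, none or still open, it means among the compounds named here.

Three compounds sharing one core, differing only in the saturated ring attached to the thiocarbonyl carbon, have been measured in a functional assay on A-431 cells (Homo sapiens) for cytotoxicity, read by MTT assay, with a stated time of 72 h, tested at 30 uM; on this read-out higher numbers stand for more inhibition of growth at the one concentration tested and lower numbers for less inhibition of growth. Compound 1 `Cc1cccc(/C(N)=N/NC(=S)N2CCCCC2)n1` gives 65.2% in this assay. Compound 3 `Cc1cccc(/C(N)=N/NC(=S)N2CCCC2)n1` gives 72.2% in this assay. Compound 2 `N/C(=N\NC(=S)N1CCOCC1)c1ccccn1`, built on a slightly different core, gives 78.8% in this assay. Compound 3 stands second of these three numbers, but its gaps to compound 2 and to compound 1 both lie within the usual scatter, so no order among the three can be claimed. Among the compounds with values here, the one step that swaps only the ring, a number 7 percentage points higher from compound 1 to compound 3 (within the scatter), stays within the scatter as well.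

Compound 4 `Cc1cccc(/C(N)=N/NC(=S)N2CCOCC2)n1` is the next member of the series, and differs from compound 3 as follows: morpholin-4-yl in place of pyrrolidin-1-yl on a thiocarbonyl carbon. Within the data shown here, the single comparable step, from piperidin-1-yl to pyrrolidin-1-yl, changed little, and compound 2, which already carries morpholin-4-yl, sits within the scatter of compound 3. The step is therefore expected to be small, a number 2.8 percentage points higher from compound 3 to compound 4 (within the scatter), with no change beyond the scatter in either direction. Compound 4 is estimated to give about 75% in this assay, most likely between 60% and 88%.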

Compound 4, percent growth inhibition at one concentration: 80%
Compound 4: the middle estimate sits 5 percentage points below what was measured; measured number inside the range.
By their numbers in this assay, from the lowest: compounds 1, 3, 2 and 4 (each within the scatter of the next, the first and the last beyond it).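

In this assay the ring on the thiocarbonyl carbon gives its first step beyond the scatter: swapping piperidin-1-yl for morpholin-4-yl gives a number 14.8 percentage points higher from compound 1 to compound 4 (beyond the scatter), a modest change. The swap of pyrrolidin-1-yl for morpholin-4-yl gives a number 7.8 percentage points higher from compound 3 to compound 4 (within the scatter) and stays within the scatter, like the earlier step between compound 1 and compound 3, so compound 3 cannot be separated from either compound with a six-membered ring, and only those two stand apart. The methyl on an aromatic carbon can now be read as a single change, and with a number 1.2 percentage points higher from compound 2 to compound 4 (within the scatter) as its whole effect, it makes no readable difference while morpholin-4-yl is in place.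

Nothing available explains why morpholin-4-yl and piperidin-1-yl differ. Still open, going by these compounds, is how a piperazin-1-yl ring or an open-chain dimethylamino group would read on the thiocarbonyl carbon, and whether the small gap between compound 1 and compound 4 would hold at other concentrations, as every number here comes from a single concentration.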